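Vinyl sulfone catechols: sulfonyl substituent swap from compound 2

This account rests on a few compounds, and the source may have more. Where it says the series, first, only, none or still open, it means among the compounds named here.

Measured so far:
compound 1 `C=CCCCCCCS(=O)(=O)/C=C/c1ccc(O)c(O)c1` — 6400 nM
compound 2 `O=S(=O)(/C=C/c1ccc(O)c(O)c1)CC1CCCN1` — 13800 nM
compound 3 `CCCCCCCCCCCS(=O)(=O)/C=C/c1ccc(O)c(O)c1` — 11400 nM

All three share the catechol vinyl sulfone core and differ only in the group on the sulfonyl sulfur. In a functional assay, read by fluorescence and spectrophotometry, with a stated time of 1 h (on this read-out lower numbers stand for an effect already at smaller amounts and higher numbers for an effect only at larger amounts of compound), compound 2 gives 13800 nM, the highest number of the three; its gap to compound 3 is within the scatter, while the gap to compound 1, a 2.2-fold higher number from compound 1 to compound 2 (0.33 log units; beyond the scatter), is beyond it. The step from compound 1 to compound 3 was a 1.8-fold higher number from compound 1 to compound 3 (0.25 log units; within the scatter).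

Compound 4 `O=S(=O)(/C=C/c1ccc(O)c(O)c1)CCCC1CCCC1` is the next point. Against compound 2 the change is 2-cyclopentylethyl in place of pyrrolidin-2-yl on a saturated chain carbon bound to a sulfonyl sulfur.

The step from compound 1 to compound 2, in which the pyrrolidin-2-yl entered, is the one that bears on this: it raised the number modestly. Compound 4 removes the same pyrrolidin-2-yl and returns to an all-carbon group, so the reverse of that step is the natural expectation. The step from compound 1 to compound 3, between two all-carbon groups, stayed within the scatter, so the length of the carbon piece is not expected to add much on its own.

For compound 4 a modest lowering, a 2.1-fold lower number from compound 2 to compound 4 (0.33 log units; beyond the scatter), is therefore expected because a 2.2-fold higher number from compound 1 to compound 2 (0.33 log units; beyond the scatter). Compound 4 is estimated at 6500 nM in this assay, with a likely range of 3000 nM to 14000 nM.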

Compound 4, half-maximal effective concentration: 6300 nM
Compound 4: middle estimate off by 1.0-fold (0.01 log units), on the high side; low and high end bracket the measured number.
By their numbers in this assay, from the lowest: compounds 4, 1, 3 and 2 (each within the scatter of the next, the first and the last beyond it).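

In this assay, 2-cyclopentylethyl in place of pyrrolidin-2-yl on a saturated chain carbon bound to a sulfonyl sulfur gives a 2.2-fold lower number from compound 2 to compound 4 (0.34 log units; beyond the scatter), so a modest step beyond the scatter also appears when a ring with a hetero atom gives way to a ring of carbon only. A ring of carbon only does not set compound 4 apart from the open-chain groups: a 1.0-fold lower number from compound 1 to compound 4 (0.01 log units; within the scatter) and a 1.8-fold lower number from compound 3 to compound 4 (0.26 log units; within the scatter) both stay within the scatter. Going by these compounds alone, compound 2, the only one here carrying a ring nitrogen, is separated beyond the scatter from compounds 1 and 4, but its gap to compound 3 stays within the scatter, and compound 3 therefore goes against a clean split between the nitrogen-bearing group and the all-carbon groups.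

The loss of the ring nitrogen and the gain of a longer link to the ring change together in this step, and a cyclopentyl on the same chain carbon or a 2-(pyrrolidin-2-yl)ethyl group would separate the two. Nothing at hand accounts for the step itself.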